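Cyclobutyl for tert-butyl on the aminoquinoline cinnamide core

This account rests on a few compounds, and the source may have more. Where it says the series, first, only, none or still open, it means among the compounds named here.

Measured so far:
compound 1 `CC(C)(C)c1cc(N)c2cc(NC(=O)/C=C/c3ccc(C(F)(F)F)cc3)ccc2n1` — 29 nM
compound 2 `CCCc1cc(N)c2cc(NC(=O)/C=C/c3ccc(C(C)(C)C)cc3)ccc2n1` — 910 nM

In a functional assay on HEK293 cells for activation of melanin-concentrating hormone receptor 1 (Homo sapiens), read by inositol phosphate accumulation (on this read-out higher numbers stand for an effect only at larger amounts of compound and lower numbers for an effect already at smaller amounts), compound 1 gives 29 nM and shows the lowest number of the two measured compounds. Compound 2 differs from it in more than one place and gives 910 nM, a much higher number, well outside the usual scatter; with two changes at once, that gap cannot be attributed to either of them.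

Compound 3 `Nc1cc(C2CCC2)nc2ccc(NC(=O)/C=C/c3ccc(C(F)(F)F)cc3)cc12` keeps the shared core and the trifluoromethyl-substituted cinnamide of compound 1 and changes a single group: cyclobutyl in place of tert-butyl on an aromatic carbon. Among the compounds with values here, both groups are four-carbon saturated fragments without donors or acceptors, and no measured pair isolates this exchange, so there is no step in this assay to lean on.

The expectation is therefore a small move, if any, with compound 3 staying near compound 1; estimated step a 1.7-fold higher number from compound 1 to compound 3 (0.24 log units; within the scatter). In this assay compound 3 is expected to give about 50 nM, within a range from 15 nM to 200 nM.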

Compound 3, half-maximal effective concentration: 250 nM
Estimate against measurement, compound 3: 5.0-fold (0.70 log units) below; the whole stated range lies below it.
By their numbers in this assay, from the lowest: compound 1; then compound 3; then compound 2.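

In this assay, within the data shown here, cyclobutyl in place of tert-butyl on the aromatic carbon next to the ring nitrogen gives an 8.6-fold higher number from compound 1 to compound 3 (0.94 log units; beyond the scatter), the first step that isolates a single place, and it lies beyond the scatter. The position therefore does not treat these two groups as interchangeable: each has 4 heavy atoms, all carbon, with 0 hydrogen-bond donors, 0 hydrogen-bond acceptors and no net charge, and the difference that the counts show is the four-membered ring of cyclobutyl. Nothing on hand explains the step.

Compound 2 still differs from compound 1 and from compound 3 in more than one place, so the compounds shown do not reveal whether the same step would appear with the tert-butyl-substituted cinnamide of compound 2. On these data alone, with only tert-butyl and cyclobutyl compared at this position on the shared core, it also remains open where other groups such as isopropyl, cyclopropyl, cyclopentyl or a phenyl ring would fall relative to compound 1.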